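The source may hold more compounds than are shown below. What is called first, only, known or untested is meant among the compounds shown, and "the series" means these compounds.

Measured so far in a functional assay on MCF7 cells (Homo sapiens) for antiproliferative activity, read by MTT assay, with a stated time of 24 h; a higher number here means a weaker inhibitor, a lower number a stronger inhibitor:
- compound 1 `CCCCc1oc2ccccc2c1C(=O)c1ccc(OCC(=O)N2CCCC2)cc1`: 42400 nM
- compound 2 `CCCCc1oc2ccccc2c1C(=O)c1ccc(OCC(=O)N2CCOCC2)cc1`: 34000 nM
- compound 3 `CCCCc1oc2ccccc2c1C(=O)c1ccc(OCCCC(=O)N2CCCC2)cc1`: 23500 nM

Compound 1 carries the highest of the three numbers, but its steps to both other compounds fall within the scatter, so the three measured values are not separated in this assay.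

The next compound, compound 4 `CCCCc1oc2ccccc2c1C(=O)c1ccc(OCCCC(=O)N2CCOCC2)cc1`, is reached from compound 1 by a single counted change: 2-((morpholin-4-yl)carbonyl)ethyl in place of (pyrrolidin-1-yl)carbonyl on a saturated chain carbon bound to an oxygen on an aromatic ring. This change combines two moves already seen separately. Exchange of the ring on the carbonyl carbon alone gave a 1.2-fold lower number from compound 1 to compound 2 (0.10 log units; within the scatter). Lengthening of the chain alone gave a 1.8-fold lower number from compound 1 to compound 3 (0.26 log units; within the scatter). The two are also linked through a 1.4-fold lower number from compound 2 to compound 3 (0.16 log units; within the scatter). Each of these steps stays within the scatter, and none points toward a higher number.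

If the two moves simply add, compound 4 should sit somewhat lower than compound 1, by roughly the product of the two small steps, but still not clearly beyond the scatter of compound 3. Compound 4 is therefore expected at 20000 nM, within 9000 nM to 45000 nM. The step that this estimate is expected to mean is a 2.1-fold lower number from compound 1 to compound 4 (0.33 log units; beyond the scatter).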

Compound 4, half-maximal inhibitory concentration: 41200 nM
The estimate for compound 4 lay 2.1-fold (0.31 log units) below the measured number, within the range that was stated.
By their numbers in this assay, from the lowest: compounds 3, 2, 4 and 1 (each within the scatter of the next).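

Taken together, the two moves leave the number where it started, with 2-((morpholin-4-yl)carbonyl)ethyl in place of (pyrrolidin-1-yl)carbonyl on a saturated chain carbon bound to an oxygen on an aromatic ring giving a 1.0-fold lower number from compound 1 to compound 4 (0.01 log units; within the scatter) in this assay. Going by these compounds alone, the other two new steps stay inside the same band, with morpholin-4-yl in place of pyrrolidin-1-yl on a carbonyl carbon giving a 1.8-fold higher number from compound 3 to compound 4 (0.24 log units; within the scatter), and the change of chain with the morpholin-4-yl ring held constant giving a 1.2-fold higher number from compound 2 to compound 4 (0.08 log units; within the scatter), so no step among the four compounds is separated from the scatter. The ring exchange, now readable at both chain lengths, has no direction that can be relied on, since its two readings carry opposite signs yet do not differ beyond what two such steps allow: the same change on two cores in this assay, a 1.2-fold lower number (0.10 log units; within the scatter) from compound 1 to compound 2 and a 1.8-fold higher number (0.24 log units; within the scatter) from compound 3 to compound 4, 2.2-fold (0.34 log units) apart, within the scatter of two such steps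

As far as these compounds go, whether anything at this position moves the number clear of the scatter remains open, for example a piperazin-1-yl group on the carbonyl carbon, a free carboxylic acid in place of the amide, or a longer chain. Neither ring nor chain length can be ranked from these four compounds, and whether the two moves interact at all remains unresolved.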